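From 3-Cyanophenyl to 3-Chloro-4-fluorophenyl on the Sulfonyl Sulfur

The source may report more compounds than this note shows. Statements on the series, on what has been measured and on what is new or still open speak of the compounds shown alone.

Three measured compounds share one core and differ only in the aromatic rings attached to it. Compound 3 `N#Cc1cccc(S(=O)(=O)c2cnc3cc(F)ccc3c2-c2ccccc2F)c1` carries a 3-cyanophenyl on the sulfonyl sulfur, and in an ADME assay on microsomes from liver (Homo sapiens) for metabolic stability, tested at 2.5 uM (on this read-out higher numbers stand for fast clearance and lower numbers for slow clearance), compound 3 gives 1.39 mL/min. Compound 2 `O=S(=O)(c1cc(Cl)cc(Cl)c1)c1cnc2cc(F)ccc2c1-c1ccccc1F` gives 0.93 mL/min in this assay, a gap within the usual scatter, while compound 1 `O=S(=O)(c1ccc(F)c(Cl)c1)c1cnc2cc(F)ccc2c1-c1ccc(Cl)cc1` gives 0.39 mL/min, a lower number beyond the scatter. Within the data shown here, the only measured single step, a 1.5-fold higher number from compound 2 to compound 3 (0.17 log units; within the scatter), shows that exchanging one ring on the sulfonyl sulfur for another left the number essentially where it was.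

Among the measured compounds shown here, compound 4 `O=S(=O)(c1ccc(F)c(Cl)c1)c1cnc2cc(F)ccc2c1-c1ccccc1F` has not yet been measured. 3-chloro-4-fluorophenyl in place of 3-cyanophenyl on a sulfonyl sulfur The same 3-chloro-4-fluorophenyl sits on the sulfonyl sulfur of compound 1, whose number in this assay is lower than that of compound 3, but compound 1 also carries a different ring elsewhere, so no measured step isolates this change. The step from compound 2 to compound 3 was small. An expected shift of a 2.3-fold lower number from compound 3 to compound 4 (0.36 log units; beyond the scatter) toward the side of compound 1 therefore seems reasonable. Compound 4 is estimated at 0.6 mL/min, with a range from 0.3 mL/min to 1.2 mL/min.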

Compound 4, intrinsic clearance in a liver preparation (reported as CLH), per the amount of preparation that the assay uses: 1.07 mL/min
Estimate against measurement, compound 4: 1.8-fold (0.25 log units) below; the measured number falls inside the stated range.
By their numbers in this assay, from the lowest: compound 1; then compounds 2, 4 and 3 (each within the scatter of the next).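

Across the three rings compared on the sulfonyl sulfur, the number in this assay hardly responds to the exchange: 3-chloro-4-fluorophenyl in place of 3-cyanophenyl gives a 1.3-fold lower number from compound 3 to compound 4 (0.11 log units; within the scatter) and 3-chloro-4-fluorophenyl in place of 3,5-dichlorophenyl gives a 1.2-fold higher number from compound 2 to compound 4 (0.06 log units; within the scatter) on the same core, so these three rings cannot be told apart at this position. The difference between compound 1 and the others therefore traces to the other ring, since 2-fluorophenyl in place of 4-chlorophenyl on an aromatic carbon gives a 2.7-fold higher number from compound 1 to compound 4 (0.44 log units; beyond the scatter) and is the only single change shown that lies beyond the usual scatter. The data shown offer no measurement that explains either the flat response on the sulfonyl sulfur or the step at the other ring.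

From the compounds shown here alone, whether the step at the aromatic carbon would be similar with 3-cyanophenyl or 3,5-dichlorophenyl on the sulfonyl sulfur remains open, as it rests on one pair of compounds. Also open is how the number would respond if a phenyl carrying an amine or a carboxylic acid sat on the sulfonyl sulfur, since every ring shown there bears only halogens or a nitrile.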